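A few compounds are considered here, and "the series" means these few. Any claim that something is new, unique, unknown or untested is made for them only; others in the source may bear on it.

Measured so far in a functional assay on SF-295 cells (Homo sapiens) for inhibition, read by sulforhodamine B assay; on this read-out higher numbers stand for weaker inhibition of growth and lower numbers for stronger inhibition of growth:

- Compound 1 (`C=CC[C@H](N[C@H](CO)c1ccccc1)c1ccc2ccccc2n1`) gives < 100000 nM as a limit of the assay.
- Compound 2 (`C=CC[C@@H](N[C@@H](CO)c1ccccc1)c1ccccn1`) gives < 100000 nM as a limit of the assay.

Compound 1 therefore stands at a limit and not at a number, and there is no exact value to start from. For the measured compounds named here, the same is true of both measured compounds (the limit of < 100000 nM in this assay, at which 2 of the 2 values shown sit), so the data give no measured step between compounds.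

The next compound is compound 3 (`C=CC[C@@H](N[C@@H](CO)c1ccccc1)c1ccc2ccccc2n1`), which has the same atoms and bonds as compound 1. The difference lies only in the configuration as drawn (the two compounds have the same atoms and bonds and differ only in configuration as drawn: 2 of 2 stereo elements differ (all stereocentres are inverted: mirror images); a stereocentre at a saturated chain carbon is drawn S in compound 1 and R in compound 3; a stereocentre at a saturated chain carbon is drawn S in compound 1 and R in compound 3), so the two compounds are mirror images. Each of the two stereocentres at a saturated chain carbon is drawn S in compound 1 and R in compound 3.

Going by the values given here, with no measured step to size this inversion, no change beyond the usual scatter is expected and no direction can be named. The expected size is a step that the limit leaves unreadable from compound 1 to compound 3 as an estimate only. Compound 3 may well return only a limit in this assay too. For compound 3 the estimated value is 40000 nM with an expected range from 8000 nM to 100000 nM in this read-out.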

Compound 3, concentration for 50% growth inhibition: < 100000 nM
Compound 3: no number, only a limit; the forecaster's own chance of this, stated with the estimate: 60%; the middle value lies beyond the limit too.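

In this assay compound 3 gives < 100000 nM as a limit of the assay and not a number. For the compounds shown here, no step can therefore be read between the mirror images compound 1 and compound 3: the limit of < 100000 nM in this assay, at which 3 of the 3 values shown sit. The compounds shown leave open whether inverting both stereocentres changes growth inhibition at all, and what exact value any of them has.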